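This account rests on a few compounds, and the source may have more. Where it says the series, first, only, none or still open, it means among the compounds named here.

Within the data shown here, compound 2 `Cc1nc(-c2ccc(C(F)(F)F)cc2)sc1COc1ccc2c(c1)OCC2CC(=O)O` has the lowest of the two numbers so far in a functional assay on CHO cells for agonist activity at Free fatty acid receptor 1 (Homo sapiens), read by FLIPR and calcium flux (a higher number here means that more compound is needed for the effect, a lower number that less compound is needed), where compound 2 gives 96.7 nM; compound 1 `Cc1nc(-c2cccc(Cl)c2)sc1COc1ccc2c(c1)OCC2CC(=O)O` gives 138 nM, and the move from compound 1 to compound 2 a 1.4-fold lower number from compound 1 to compound 2 (0.15 log units; within the scatter) kept both within the scatter. Compound 3 `COc1ccc(-c2nc(C)c(COc3ccc4c(c3)OCC4CC(=O)O)s2)cc1` carries methoxy in place of trifluoromethyl on an aromatic carbon. Among the measured compounds shown here, the one step that bears on it, the change of the aromatic group, stayed small, so no step beyond the scatter is expected here, with the number expected to stay close a 1.6-fold higher number from compound 2 to compound 3 (0.19 log units; within the scatter). Compound 3 is estimated at 150 nM, likely between 50 nM and 450 nM.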

Compound 3, half-maximal effective concentration: 123 nM
Estimate against measurement, compound 3: 1.2-fold (0.09 log units) above; low and high end bracket the measured number.
By their numbers in this assay, from the lowest: compounds 2, 3 and 1 (each within the scatter of the next).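

In this assay, methoxy in place of trifluoromethyl on this aromatic carbon gives a 1.3-fold higher number from compound 2 to compound 3 (0.10 log units; within the scatter) and the wider swap of the aromatic group gives a 1.1-fold lower number from compound 1 to compound 3 (0.05 log units; within the scatter) so all these steps stay within the scatter. At this position, methoxy counts a hydrogen-bond acceptor and trifluoromethyl none, yet this difference leaves the number within the scatter. Nothing measured here explains why the numbers stay so close. Going by these compounds, whether an amine or a carboxylic acid on this carbon, or a longer chain in place of methoxy, would move the number beyond the scatter remains open.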